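This account rests on a few compounds, and the source may have more. Where it says the series, first, only, none or still open, it means among the compounds named here.

Compound 1 `CN(c1cccc2c1CCCC2c1c[nH]cn1)S(C)(=O)=O` gives 708 nM in an assay on isolated protein for binding affinity to Alpha-1D adrenergic receptor (Rattus norvegicus), read by radioligand binding; a higher number here means a weaker inhibitor, a lower number a stronger inhibitor.
Compound 3 `O=S(=O)(Nc1cccc2c1CCCC2c1c[nH]cn1)C1CC1` gives 2690 nM in this assay.
Compound 2 `CCCS(=O)(=O)Nc1cccc2c1CCCC2c1c[nH]cn1` reaches only a limit of this assay, < 10000 nM.

Compound 2 therefore stands at a limit rather than at a number, and the steps a step that the limit leaves unreadable from compound 1 to compound 2 and a step that the limit leaves unreadable from compound 2 to compound 3 cannot be read because of the limit of < 10000 nM in this assay, at which 1 of the 3 values shown sits. Compound 4 `Oc1cccc2c1CCCC2c1c[nH]cn1` differs from compound 2 by hydroxy in place of (propylsulfonyl)amino on an aromatic carbon. Going by the values given here, the only readable step, a 3.8-fold higher number from compound 1 to compound 3 (0.58 log units; beyond the scatter), swaps one group on the sulfonyl sulfur for another and keeps the sulfonamide, so it bears on removing the whole sulfonamide only loosely. With the starting point itself a limit, no direction can be read for the new step. Compound 4 is estimated at 2000 nM, within 300 nM to 15000 nM. That estimate would mean an expected step that the limit leaves unreadable from compound 2 to compound 4.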

Compound 4, inhibition constant: 30.9 nM
The estimate for compound 4 lay 65-fold (1.81 log units) above the measured number; measured number outside the range, below it.
By their numbers in this assay, from the lowest: compound 4; then compound 1; then compound 3.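

Replacing a sulfonamide with hydroxy on this aromatic carbon brings large drops in this assay: an 87-fold lower number from compound 3 to compound 4 (1.94 log units; beyond the scatter) and a 23-fold lower number from compound 1 to compound 4 (1.36 log units; beyond the scatter). The sulfonamide is therefore not needed at this position for a low number, and both readable steps point the same way. Compound 2 stands at a limit, so its step to hydroxy cannot be read: the limit of < 10000 nM in this assay, at which 1 of the 4 values shown sits.

Still open, from the compounds shown here alone, is whether a methoxy or a plain amine on this carbon would keep the number as low as hydroxy does.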